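The source may report more compounds than this note shows. Statements on the series, on what has been measured and on what is new or still open speak of the compounds shown alone.

Of the compounds shown here, two have been measured in an ADME assay on the whole organism (strain Han-Wistar) for pharmacokinetics, with Rattus norvegicus as the target, read by LC-MS, at a dose of 2 mg/kg by the oral route; a higher number here means more compound in the circulation at the dose given, a lower number less compound in the circulation. Compound 1 `Cc1ccn(-c2ccc(Cl)c(C(=O)NC(=O)Nc3nc4ccc(S(=O)(=O)CCCN5CCN(C)CC5)cc4s3)c2)n1` gives 410 nM in this assay, and compound 2 `CN1CCN(CCCS(=O)(=O)c2ccc3nc(NC(=O)NC(=O)c4cc(-n5cccn5)ccc4Cl)sc3c2)CC1` gives 1200 nM. Among the measured compounds shown here, the one step between them, a 2.9-fold higher number from compound 1 to compound 2 (0.47 log units; beyond the scatter), places compound 2 at the higher of the two numbers.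

Compound 3 `CN1CCN(CCCS(=O)(=O)c2ccc3nc(NC(=O)NC(=O)c4cc(N5CCCC5)ccc4Cl)sc3c2)CC1` differs from compound 2 by pyrrolidin-1-yl in place of 1H-pyrazol-1-yl on an aromatic carbon. For the measured compounds named here, no measured step touches this part of the molecule: the only step in hand, a 2.9-fold higher number from compound 1 to compound 2 (0.47 log units; beyond the scatter), swaps a hydrogen for a methyl on the group that is now being replaced altogether, so it tells little about exchanging that whole group for another. Going by the values given here, with no closer precedent, no change beyond the scatter is expected, and the estimate is held loosely. Compound 3 is therefore expected to give about 900 nM in this assay, within a range of 300 nM to 2700 nM, an expected step of a 1.3-fold lower number from compound 2 to compound 3 (0.12 log units; within the scatter) from compound 2.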

Compound 3, maximal plasma concentration: 640 nM
Compound 3: the middle estimate sits 1.4-fold (0.15 log units) above what was measured; measured number inside the range.
By their numbers in this assay, from the lowest: compounds 1, 3 and 2 (each within the scatter of the next, the first and the last beyond it).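

Among the compounds shown here, exchanging the aromatic 1H-pyrazol-1-yl for the non-aromatic pyrrolidin-1-yl gives, in this assay, a 1.9-fold lower number from compound 2 to compound 3 (0.27 log units; within the scatter), the first reading of a non-aromatic ring at this position. Replacing 3-methyl-1H-pyrazol-1-yl with the same ring gives a 1.6-fold higher number from compound 1 to compound 3 (0.19 log units; within the scatter), so pyrrolidin-1-yl cannot be told apart from either aromatic ring, even though those two rings differ from each other beyond the scatter. Nothing measured here explains these numbers.

The compounds shown leave open whether a ring is needed at this carbon at all, since a plain hydrogen or an open-chain dimethylamino group could read differently. They also leave open how a larger non-aromatic ring, such as morpholin-4-yl or piperidin-1-yl, would behave in this position.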